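Returning to a Pyrimidine on the Sulfonamide Nitrogen

The compounds below may be only part of what the source reports. "The series", "measured", "known", "first", "only" and "open" are said of these compounds alone.

Compound 2 `C=C1CC[C@@H]2[C@](C)(COC(C)=O)[C@H](OC(C)=O)CC[C@@]2(C)[C@H]1CC(Nc1ccc(S(=O)(=O)Nc2nccs2)cc1)C1=CCOC1=O` was tested in a functional assay on UACC-62 cells (Homo sapiens) for inhibition, read by sulforhodamine B assay, with a stated time of 48 h (a lower number here means that less compound is tolerated, a higher number that more compound is tolerated), where compound 2 gives 13500 nM. Within the data shown here, compound 1 `C=C1CC[C@@H]2[C@](C)(COC(C)=O)[C@H](OC(C)=O)CC[C@@]2(C)[C@H]1CC(Nc1ccc(S(=O)(=O)Nc2nccc(C)n2)cc1)C1=CCOC1=O` in this assay gives 30300 nM, so compound 2 stands lowest of the two numbers, with compound 1 as its only neighbour. Among the measured compounds shown here, the one measured step, a 2.2-fold lower number from compound 1 to compound 2 (0.35 log units; beyond the scatter), put 1,3-thiazol-2-yl in place of 4-methylpyrimidin-2-yl on a sulfonamide nitrogen. Compound 3 `C=C1CC[C@@H]2[C@](C)(COC(C)=O)[C@H](OC(C)=O)CC[C@@]2(C)[C@H]1CC(Nc1ccc(S(=O)(=O)Nc2ncccn2)cc1)C1=CCOC1=O` differs from compound 2 as follows: pyrimidin-2-yl in place of 1,3-thiazol-2-yl on a sulfonamide nitrogen. This largely reverses the earlier change, restoring a pyrimidine ring, though without the methyl that compound 1 carries. For the measured compounds named here, only that single step bears on the question, and it was modest, so compound 3 is expected to move back towards compound 1 by an estimated 1.6-fold higher number from compound 2 to compound 3 (0.21 log units; within the scatter). The estimate for compound 3 in this assay is 22000 nM, with a likely range from 10000 nM to 45000 nM.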

Compound 3, concentration lethal to 50% of the cells: 5910 nM
Compound 3: middle estimate off by 3.7-fold (0.57 log units), on the high side; the whole stated range lies above it.
By their numbers in this assay, from the lowest: compound 3; then compound 2; then compound 1.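

In this assay, restoring a pyrimidine ring did not carry the number back towards compound 1; instead, it fell further, with a 2.3-fold lower number from compound 2 to compound 3 (0.36 log units; beyond the scatter). The methyl group on the pyrimidine also matters, since hydrogen in its place on an aromatic carbon gives a 5.1-fold lower number from compound 1 to compound 3 (0.71 log units; beyond the scatter). Ring type alone therefore does not set the number at this sulfonamide nitrogen: compound 2, with its 1,3-thiazol-2-yl group, falls between the two pyrimidine compounds.

The compounds shown leave open whether a methoxy group or a chlorine atom on that same aromatic carbon would give a number nearer compound 1 or compound 3. No experimental evidence is available to explain the order of these three compounds.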